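Quinazoline series: aminophenyl substituent at the anilino nitrogen

The compounds below may be only part of what the source reports. "The series", "measured", "known", "first", "only" and "open" are said of these compounds alone.

Measured compounds:
Compound 1, `Fc1cccc(-c2nc(Nc3ccccc3F)c3cc(F)ccc3n2)c1`. In a functional assay on U2OS cells (Homo sapiens) for cytotoxicity, read by MTT assay, with a stated time of 48 h (a higher number here means a weaker inhibitor, a lower number a stronger inhibitor), compound 1 gives > 50000 nM, which is a limit of the assay and not a number.
Compound 2, `Fc1cccc(-c2nc(Nc3cccc(Cl)c3)c3cc(F)ccc3n2)c1`. In this assay compound 2 gives > 50000 nM, again a limit of the assay.
Compound 3, `Fc1cccc(-c2nc(Nc3ccccc3Cl)c3cc(F)ccc3n2)c1`. In this assay compound 3 gives > 50000 nM, also a limit of the assay.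

Compound 3 therefore stands only at a limit; its position relative to the other two cannot be placed on a number, and all three values sit together, as the limit of > 50000 nM in this assay, at which 3 of the 3 values shown sit, records. The steps between the measured compounds are all unreadable for the same reason: a step that the two limits leave unreadable from compound 1 to compound 2, a step that the two limits leave unreadable from compound 1 to compound 3 and a step that the two limits leave unreadable from compound 2 to compound 3.

The next compound, compound 4, `Nc1cccc(Nc2nc(-c3cccc(F)c3)nc3ccc(F)cc23)c1`, differs from compound 3 by 3-aminophenyl in place of 2-chlorophenyl on a nitrogen on an aromatic ring. The two steps that bear on it, from compound 1 to compound 2 and from compound 2 to compound 3, both exchange substituents on the phenyl ring attached to the anilino nitrogen, and neither gives a readable size. No direction can be drawn from them. The expected step of a number no higher from compound 3 to compound 4 (the limit leaves the size open) is therefore set at none beyond the scatter, with the value of compound 4 most likely again at the limit. Compound 4 is estimated at 50000 nM, with a range from 15000 nM to 150000 nM.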

Compound 4, half-maximal inhibitory concentration: 49700 nM
Estimate against measurement, compound 4: 1.0-fold (0.00 log units) above; the range from low to high includes it.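

Within the data shown here, compound 4, carrying 3-aminophenyl on the nitrogen, is the first compound to give a number and not a limit: in this assay compound 4 gives 49700 nM, with a number no higher from compound 3 to compound 4 (the limit leaves the size open), a number no higher from compound 2 to compound 4 (the limit leaves the size open) and a number no higher from compound 1 to compound 4 (the limit leaves the size open). None of these steps can be read in size, so this change shows neither a real gain nor its absence. The position now has one measured value, while the rest of the record stays at a single limit: the limit of > 50000 nM in this assay, at which 3 of the 4 values shown sit.

As far as these compounds go, whether a hydroxyl, a methoxy or an acetylated amine on this phenyl ring would give a value clearly lower than that of compound 4 stays open. Also open, from the compounds shown here alone, is whether the amino group would give a number when placed elsewhere on the ring, as in 2-aminophenyl, or when paired with other groups on the shared core.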